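This account rests on a few compounds, and the source may have more. Where it says the series, first, only, none or still open, it means among the compounds named here.

Compound 1 `COc1ccc(-c2cc(C(=O)/C=C/c3cc(OC)c(OC)c(OC)c3)ccc2N)cc1OC` was examined in a functional assay on MCF7 cells (Homo sapiens) for cytotoxicity, read by sulforhodamine B assay, with a stated time of 48 h (a lower number here means a stronger inhibitor, a higher number a weaker inhibitor), where compound 1 gives 6580 nM. Compound 3 `COc1cc(/C=C/C(=O)c2ccc(N)c(-c3ccc(F)cc3)c2)cc(OC)c1OC` carries 4-fluorophenyl in place of 3,4-dimethoxyphenyl on an aromatic carbon and in this assay compound 3 gives 9030 nM; the step of a 1.4-fold higher number from compound 1 to compound 3 (0.14 log units; within the scatter). Compound 2 `COc1ccc(-c2cc(C(=O)/C=C/c3cccc(OC)c3OC)ccc2N)cc1OC` shows 10200 nM in this assay; the difference between the core of compound 2 and the core of compound 1 is not broken down here. Compound 4 `COc1cccc(/C=C/C(=O)c2ccc(N)c(-c3ccc(F)cc3)c2)c1OC` has not yet been measured. It differs from compound 2 by 4-fluorophenyl in place of 3,4-dimethoxyphenyl on an aromatic carbon, the same change as from compound 1 to compound 3, at the same place. The step from compound 2 to compound 4 is expected to be a 1.3-fold higher number from compound 2 to compound 4 (0.11 log units; within the scatter) because the earlier step of a 1.4-fold higher number from compound 1 to compound 3 (0.14 log units; within the scatter) stayed within the scatter. Compound 4 is therefore estimated at 13000 nM in this assay, with a range from 6000 nM to 28000 nM.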

Compound 4, half-maximal inhibitory concentration: 13300 nM
Compound 4: the middle estimate sits 1.0-fold (0.01 log units) below what was measured; low and high end bracket the measured number.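

In this assay, 4-fluorophenyl in place of 3,4-dimethoxyphenyl gives a 1.3-fold higher number from compound 2 to compound 4 (0.12 log units; within the scatter) on the core of compound 2, and this step agrees with the earlier one on the core of compound 1: the same change on two cores in this assay, a 1.4-fold higher number (0.14 log units; within the scatter) from compound 1 to compound 3 and a 1.3-fold higher number (0.12 log units; within the scatter) from compound 2 to compound 4, 1.1-fold (0.02 log units) apart, within the scatter of two such steps. Across these two cores, the change therefore carries over without a difference that can be told from the scatter. This does not show that either group affects the read-out, as neither step lies beyond the scatter, and it says nothing about any other core.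

The compounds shown leave open how a pyridine or a phenyl ring bearing a carboxylic acid would behave in the place of these two groups. They also leave open what an acetamide in place of the amino group would do on either core.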